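A Fluorine Added on the Outer Phenyl Ring

The compounds below may be only part of what the source reports. "The series", "measured", "known", "first", "only" and "open" are said of these compounds alone.

In a functional assay on OVCAR-3 cells (Homo sapiens) for antiproliferative activity, read by MTT assay, with a stated time of 24 h (on this read-out higher numbers stand for weaker inhibition and lower numbers for stronger inhibition), the measured compounds are:
compound 1 `O=c1[nH]cc(S(=O)(=O)Nc2ccccc2-c2cn(-c3ccccc3)nn2)c(=O)[nH]1`, which gives 6650 nM;
compound 2 `O=c1[nH]cc(S(=O)(=O)Nc2cccc(-c3cn(-c4cccc(F)c4)nn3)c2)c(=O)[nH]1`, which gives only the limit > 20000 nM;
compound 3 `O=c1[nH]cc(S(=O)(=O)Nc2ccc(-c3cn(-c4ccccc4)nn3)cc2)c(=O)[nH]1`, which gives 18000 nM.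

Compound 3 holds the highest of the two numbers shown. The nearest number belongs to compound 1, and the gap between compound 1 and compound 3 lies beyond the usual scatter of repeated measurements. Compound 2 reaches only a limit, namely (the limit of > 20000 nM in this assay, at which 1 of the 3 values shown sits), so it adds no number to the comparison.

Compound 4 `O=c1[nH]cc(S(=O)(=O)Nc2ccc(-c3cn(-c4ccc(F)cc4)nn3)cc2)c(=O)[nH]1` differs from compound 3 by a single change: fluoro in place of hydrogen on an aromatic carbon, sitting para to a large group, so that the phenyl becomes a 4-fluorophenyl. Within the data shown here, no pair of measured compounds isolates this change. Compound 2 also carries a fluoro on its outer ring, but it differs from compound 3 in more than one place, and its value is a limit; the two values therefore show nothing about the effect of the fluoro alone. With the ring and all other groups unchanged, the step from compound 3 to compound 4 in this assay is expected to stay within the scatter, in no particular direction. Compound 4 is estimated to give about 18000 nM, within a range from 8000 nM to 40000 nM, and the step of no change at the digits printed from compound 3 to compound 4 (within the scatter) is expected to be small.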

Compound 4, half-maximal inhibitory concentration: > 20000 nM
Compound 4 was reported as a limit (the forecaster's own chance of this, stated with the estimate: 35%); at least 1.1-fold (0.04 log units) between middle value and limit.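

In this assay compound 4 reaches only a limit, > 20000 nM, which is not a number. Among these compounds, this is the first pair to isolate fluoro in place of hydrogen on an aromatic carbon, para to a large group, and the reading is an at least 1.1-fold higher number from compound 3 to compound 4 (0.04 log units; that floor lies within the scatter); the change therefore brings no gain in inhibition that this read-out can show, while only a floor is known for the size of the step, and the true size remains unknown. With the phenyl turned into a 4-fluorophenyl, compound 4 sits at the limit of the assay: the limit of > 20000 nM in this assay, at which 2 of the 4 values shown sit.

How far the step from hydrogen to fluoro really reaches cannot be read from these compounds, and neither can its direction be fixed beyond that floor. The compounds shown also leave open what a chloro, a methoxy or an amine would do at this same place, and whether fluoro on the outer phenyl would read differently on compound 1, which gives 6650 nM.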